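Notes on the amide change from compound 2 to compound 4

The compounds below may be only part of what the source reports. "The series", "measured", "known", "first", "only" and "open" are said of these compounds alone.

Measured compounds:
Compound 1 `CCOc1ccc(NC(=O)c2cccc(/C=C3\CC(=O)N(Cc4ccccc4)C3=O)c2)cc1` gives 41700 nM in an ADME assay on HCT-116 cells (Homo sapiens) for cytotoxicity, read by MTT assay, with a stated time of 72 h; a lower number here means a stronger inhibitor, a higher number a weaker inhibitor.
Compound 2 `CCOc1ccc(NC(=O)c2cccc(/C=C3\CC(=O)N(c4ccccc4)C3=O)c2)cc1` gives 84800 nM in this assay.
Compound 3 `COc1ccc(NC(=O)c2cccc(CC3CC(=O)N(c4ccc(C)cc4)C3=O)c2)cc1` reports only a limit in this assay, > 100000 nM.

Compound 2 holds the highest of the two numbers; its nearest neighbour is compound 1, with a 2.0-fold higher number from compound 1 to compound 2 (0.31 log units; beyond the scatter), a change of phenyl in place of benzyl on the ring nitrogen. Compound 4 `O=C(c1cccc(/C=C2\CC(=O)N(c3ccccc3)C2=O)c1)N1CCCC1` differs from compound 2 by pyrrolidin-1-yl in place of (4-ethoxyphenyl)amino on a carbonyl carbon. No measured step concerns the carbonyl carbon, so none bears on this change; the single step shown touches another position. With the series sitting at weak inhibition and one value already a limit, as in the limit of > 100000 nM in this assay, at which 1 of the 3 values shown sits, no step beyond the scatter is expected from compound 2 to compound 4: a 1.1-fold higher number from compound 2 to compound 4 (0.03 log units; within the scatter). Compound 4 is therefore estimated at 90000 nM, within 40000 nM to 200000 nM.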

Compound 4, half-maximal inhibitory concentration: > 100000 nM
Compound 4: a limit, no number; the forecaster's own chance of this, stated with the estimate: 40%; middle value at least 1.1-fold (0.04 log units) away from the limit.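

In this assay compound 4 reports only a limit (> 100000 nM). Within the data shown here, the change on the carbonyl carbon reads as an at least 1.1-fold higher number from compound 2 to compound 4 (0.07 log units; that floor lies within the scatter) and so gives a floor rather than a size, the first reading at this position, with pyrrolidin-1-yl yielding no measurable number. The series shown now stands as follows: the limit of > 100000 nM in this assay, at which 2 of the 4 values shown sit.

As far as these compounds go, how large the step from (4-ethoxyphenyl)amino to pyrrolidin-1-yl really is stays open. Also open, from the compounds shown here alone, is whether morpholin-4-yl or benzylamino on this carbonyl carbon would return a measurable number.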